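The source may hold more compounds than are shown below. What is called first, only, known or untested is meant among the compounds shown, and "the series" means these compounds.

Compound 1 `C=C1/C=C/C(=O)/C(CO)=C\C[C@](C)(CCC=C(C)C)/C=C/[C@H]1OC(=O)C=C(C)C`: 2750 nM
Compound 2 `CC(C)=CCC[C@]1(C)/C=C/[C@@H](OC(=O)C=C(C)C)[C@](C)(O)/C=C/C(=O)/C(C=O)=C\C1`: 12600 nM
Compound 3 `CC(C)=CCC[C@](C)(/C=C/[C@@H](OC(=O)C=C(C)C)[C@](C)(O)/C=C/C(=O)/C=C/N1CCN(C)CC1)CC=O`: 8840 nM

All three compounds were tested in a functional assay on MCF7 cells (Homo sapiens) for antiproliferative activity, read by MTT assay, with a stated time of 48 h; on this read-out lower numbers stand for stronger inhibition and higher numbers for weaker inhibition. Among these numbers compound 2 gives the highest; the number of compound 3 lies within the scatter of it, while compound 1 sits beyond the scatter with a clearly lower number. Compound 4 `CC(C)=CCC[C@]1(C)/C=C/[C@@H](OC(=O)C=C(C)C)[C@](C)(O)/C=C/C(=O)/C(C(=O)N(C)C)=C\C1` has not yet been measured. It differs from compound 2 in a single place: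

dimethylamino in place of hydrogen on a carbonyl carbon

Within the data shown here, no pair of measured compounds differs in just this way, so the size of this step cannot be read from the measured values. In this assay the step is expected to be small, a 1.1-fold lower number from compound 2 to compound 4 (0.06 log units; within the scatter), not clearly beyond the scatter. Compound 4 is estimated at 11000 nM, within a range from 3500 nM to 35000 nM.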

Compound 4, half-maximal inhibitory concentration: 3670 nM
The estimate for compound 4 lay 3.0-fold (0.48 log units) above the measured number, within the range that was stated.
By their numbers in this assay, from the lowest: compounds 1 and 4 (each within the scatter of the next); then compounds 3 and 2 (each within the scatter of the next).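

On this carbonyl carbon, the change from formyl to dimethylcarbamoyl is not silent: in this assay it gives a 3.4-fold lower number from compound 2 to compound 4 (0.54 log units; beyond the scatter), beyond the usual scatter. Among these compounds, this is the first direct reading of this position, since no earlier pair differed only here. Nothing measured here accounts for the step. Still open, as far as these compounds go, is how a carboxylic acid, a methyl ester or a ring amide such as the morpholine amide would behave on this same carbon. A single step also cannot show whether the gain depends on the size of the amine part.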